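This account rests on a few compounds, and the source may have more. Where it says the series, first, only, none or still open, it means among the compounds named here.

Measured compounds:
Compound 1, `CC(C)(C)OC(=O)/C=C\NC(=O)[C@@H](O)C(C)(C)CO`, gives 26% in an ADME assay on WI-38 cells (Homo sapiens) for inhibition, read by CellTiter-Glo, with a stated time of 48 h, tested at 100 uM; a lower number here means less inhibition, a higher number more inhibition at the concentration tested (going by the name of the read-out).
Compound 2, `COC(=O)/C=C\NC(=O)[C@@H](O)C(C)(C)CO`, gives -20%.
Compound 3, `CC(C)(CO)[C@H](O)C(=O)N/C=C\C(=O)OCc1ccccc1`, gives -2%.

Among the three numbers, compound 3 stands second highest: compound 2 lies below it, as a number 18 percentage points higher from compound 2 to compound 3 (beyond the scatter) shows, while compound 1 lies above it, as a number 28 percentage points lower from compound 1 to compound 3 (beyond the scatter) shows. The remaining step, a number 46 percentage points lower from compound 1 to compound 2 (beyond the scatter), is the largest of the three, and all three steps change the group on an oxygen next to a carbonyl group.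

Compound 4, `CC(C)(CO)[C@@H](O)C(=O)N/C=C/C(=O)OCc1ccccc1`, has not yet been measured. Its relation to compound 3 is this: the two compounds have the same atoms and bonds and differ only in configuration as drawn: 2 of 2 stereo elements differ; a stereocentre at a saturated chain carbon is drawn S in compound 3 and R in compound 4; a double bond is drawn Z in compound 3 and E in compound 4. Within the data shown here, none of the measured steps touches either the stereocentre or the double bond; every one of them swaps the ester substituent, which compound 4 keeps unchanged as benzyl. The measured steps therefore give no direct footing for this change, and no shift beyond the scatter can be argued from them in either direction.

On that basis compound 4 is expected to come out close to compound 3, at about 2%, with a plausible range from -20% to 25%, meaning an expected step of a number 4 percentage points higher from compound 3 to compound 4 (within the scatter).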

Compound 4, a percentage reported as inhibition, at one concentration (the size of the read-out at that concentration, not a potency): 19%
The estimate for compound 4 lay 17 percentage points below the measured number; the measured number falls inside the stated range.
By their numbers in this assay, from the lowest: compound 2; then compound 3; then compounds 4 and 1 (each within the scatter of the next).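

The earlier steps shown here all exchanged the group on an oxygen next to a carbonyl group, whereas here the benzyl group stays in place and the number still moves, with a number 21 percentage points higher from compound 3 to compound 4 (beyond the scatter). In this assay, the ester substituent is therefore not the only feature of this series tied to a shift beyond the scatter, since a change in drawn configuration alone is enough to produce one. No atom or bond enters or leaves in this step, so the shift can be assigned to configuration as a whole: the fact that compounds 3 and 4 differ only in the configuration as drawn

Both stereo elements change at once, so the compounds shown do not tell whether the shift belongs to the stereocentre at the saturated chain carbon, to the double bond, or to the two together. They also leave open whether the same change in configuration would shift the number with tert-butyl or methyl in place of benzyl, and how a carboxylic acid in place of the ester would read out in this assay.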